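Arylpiperazine succinimide propanamides in the electroshock screen

A few compounds are considered here, and "the series" means these few. Any claim that something is new, unique, unknown or untested is made for them only; others in the source may bear on it.

Measured in a functional assay on the whole organism (strain Swiss) with Mus musculus as the target, in the maximal electroshock model, with a stated time of 2 h, at a dose of 300 mg/kg by the intraperitoneal route; a lower number here means a weaker effect, a higher number a stronger effect of the compound at the dose given:
compound 1 `CC(C(=O)N1CCN(c2ccccc2)CC1)N1C(=O)CCC1=O` gives 0%
compound 2 `CCC(C(=O)N1CCN(c2ccccc2C(F)(F)F)CC1)N1C(=O)CCC1=O` gives 0%
compound 3 `CCC(C(=O)N1CCN(c2cccc(C)c2)CC1)N1C(=O)CCC1=O` gives 0%

Compound 3 stands level with compounds 1 and 2 at the digits read; its nearest neighbour is compound 1 and its furthest is compound 2, and neither gap reaches beyond the scatter. Going by the values given here, no step between two measured compounds that differ in one place is available in this set.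

Compound 4 `CCC(C(=O)N1CCN(c2ccccc2)CC1)N1C(=O)CCC1=O` is unmeasured. It differs from compound 3 by hydrogen in place of methyl on an aromatic carbon, the change sitting on an aromatic carbon of a six-membered aromatic ring of carbon only; cut one bond further out it reads 3-methylphenyl to phenyl. Because compound 3 gives 0% in this assay and compounds 1 and 2 sit level with it, no step beyond the scatter is expected in either direction. The step of no change at the digits printed from compound 3 to compound 4 (within the scatter) is expected to stay within the scatter. Compound 4 is estimated at 0%, between 0% and 10%.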

Compound 4, a percentage reported as activity, at one dose (the size of the read-out at that dose, not a potency): 25%
For compound 4 the middle estimate is 25 percentage points below the measured one, and the stated range ends below it.
By their numbers in this assay, from the lowest: compounds 1, 2 and 3 (each within the scatter of the next); then compound 4.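

In this assay the bare phenyl ring is what separates compound 4 from its substituted relatives: hydrogen in place of methyl gives a number 25 percentage points higher from compound 3 to compound 4 (beyond the scatter) and hydrogen in place of trifluoromethyl gives a number 25 percentage points higher from compound 2 to compound 4 (beyond the scatter). The saturated chain carbon matters as well, with methyl in place of hydrogen there giving a number 25 percentage points higher from compound 1 to compound 4 (beyond the scatter). No measurement at hand accounts for these steps.

From the compounds shown here alone, whether a chlorine or a methoxy group on the phenyl ring would keep the read-out of compound 4 remains open. So does whether a longer chain on the saturated carbon would add to it.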